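A few compounds are considered here, and "the series" means these few. Any claim that something is new, unique, unknown or untested is made for them only; others in the source may bear on it.

The series shares one core, seen in compound 1 `CCN(CC(=O)N1CCC[C@H](c2ccccc2)[C@@H]1CN1CCCC1)c1ccc(Cl)c(Cl)c1`, and varies the group on the amine nitrogen of its side chain. In an assay on HEK293 cells for displacement of a labelled ligand from Urotensin-2 receptor (Homo sapiens) (on this read-out lower numbers stand for stronger inhibition and higher numbers for weaker inhibition), compound 1 gives 31.6 nM. Among the measured compounds shown here, compound 2 `CC(=O)N(CC(=O)N1CCC[C@H](c2ccccc2)[C@@H]1CN1CCCC1)c1ccc(Cl)c(Cl)c1` carries an acetyl in place of the ethyl, and in this assay compound 2 gives 1580 nM; the step of a 50-fold higher number from compound 1 to compound 2 (1.70 log units; beyond the scatter) is the only measured step in the set. Compound 3 `Cc1ccc(N(C)CC(=O)N2CCC[C@H](c3ccccc3)[C@@H]2CN2CCCC2)cc1C` keeps a methyl on that nitrogen and bears a 3,4-dimethylphenyl; in this assay compound 3 gives 200 nM, which places it second highest of the three numbers, beyond the scatter from compound 1 on one side and from compound 2 on the other.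

Compound 4 `COc1cccc(N(C)CC(=O)N2CCC[C@H](c3ccccc3)[C@@H]2CN2CCCC2)c1` differs from compound 3 in one place: 3-methoxyphenyl in place of 3,4-dimethylphenyl on an amine nitrogen. For the measured compounds named here, no measured step in this set touches the aromatic ring on the amine nitrogen; the one measured step, from compound 1 to compound 2, concerns the other substituent on that nitrogen and gives no guide to the change at hand. The expectation for compound 4 is therefore a step of a 1.3-fold higher number from compound 3 to compound 4 (0.10 log units; within the scatter), that is, none beyond the scatter, with wide uncertainty. Compound 4 is estimated at 250 nM in this assay, within 70 nM to 900 nM.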

Compound 4, inhibition constant: 794 nM
Beside the measured number, compound 4's estimate is 3.2-fold (0.50 log units) below it; measured number inside the range.
By their numbers in this assay, from the lowest: compound 1; then compound 3; then compounds 4 and 2 (each within the scatter of the next).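

Among the compounds shown here, the ring on the amine nitrogen proves to be a position that matters: in this assay the change to 3-methoxyphenyl gives a 4.0-fold higher number from compound 3 to compound 4 (0.60 log units; beyond the scatter) and is the first measured step to touch this ring, since the earlier step concerned only the other substituent on that nitrogen. The exchange leaves the count of 8 heavy atoms, the six-membered aromatic ring and the absence of net charge as they were, yet it still moves the number beyond the scatter, so the outcome at this position is not set by the size of the group as counted in heavy atoms. What does change is that one oxygen enters, with one hydrogen-bond acceptor, while two ring methyl groups give way to a single methoxy group, and the pair cannot say which of these differences matters. Nothing available here accounts for the direction or size of this step.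

Going by these compounds, whether a 3-methylphenyl or a 3-hydroxyphenyl on the same nitrogen would lie closer to compound 3 or to compound 4 remains open. So does whether the same exchange would give a similar step with ethyl rather than methyl as the other substituent on that nitrogen.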